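A longer ester-bearing side chain on the shared core

The source may report more compounds than this note shows. Statements on the series, on what has been measured and on what is new or still open speak of the compounds shown alone.

Of the compounds shown here, three carrying the same amide-linked core have been measured in a functional assay on the whole organism (Tail, strain ICR) with Mus musculus as the target, in the tail flick test, with a stated time of 30 min, at a dose of 25 umol/kg by the oral route; a higher number here means a stronger effect of the compound at the dose given, a lower number a weaker effect. Compound 1 `CC(C)[C@H](NC(=O)CN(c1nc(Cl)nc2[nH]cnc12)C1CC1)C(=O)OCc1ccccc1` gives 33.4% in this assay. Compound 2 `O=C(OCc1ccccc1)[C@@H]1CCCN1C(=O)CN(c1nc(Cl)nc2[nH]cnc12)C1CC1` gives 33.2%, and compound 3 `CC[C@H](C)[C@H](NC(=O)CN(c1ncnc2c1ncn2C1CCCCO1)C1CC1)C(=O)OCc1ccccc1` gives 25.6%. The number for compound 1 is the largest of the three, yet its gaps to compound 2 and to compound 3 both lie within the usual scatter, so no order among the three can be read from these data.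

Compound 4 `O=C(CN(c1nc(Cl)nc2[nH]cnc12)C1CC1)N[C@@H](CCC(=O)OCc1ccccc1)C(=O)OCc1ccccc1` has not been measured in this assay. It differs from compound 1 in one place: 2-(benzyloxycarbonyl)ethyl in place of isopropyl on a saturated chain carbon bound to an amide-type nitrogen and a carbonyl carbon. Within the data shown here, no pair of measured compounds shows what this kind of change does, so the expectation rests only on the values of compounds 1, 2 and 3, which all sit close together.

The step from compound 1 to compound 4 is expected to be small, a number 3.4 percentage points lower from compound 1 to compound 4 (within the scatter), with no direction beyond the scatter. Compound 4 is therefore estimated to give about 30% in this assay, within a range from 15% to 45%.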

Compound 4, a percentage reported as activity, at one dose (the size of the read-out at that dose, not a potency): 52.8%
Compound 4: the middle estimate sits 22.8 percentage points below what was measured; measured number outside the range, above it.
By their numbers in this assay, from the lowest: compounds 3, 2 and 1 (each within the scatter of the next); then compound 4.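

Among these compounds, the step shows that the place on a saturated chain carbon bound to an amide-type nitrogen and a carbonyl carbon is not indifferent in this assay: 2-(benzyloxycarbonyl)ethyl in place of isopropyl gives a number 19.4 percentage points higher from compound 1 to compound 4 (beyond the scatter), a change beyond the scatter, which the earlier compounds, all within the scatter of one another, did not show. As a single step, it shows only that the effect at this dose can rise with this replacement, not which part of the entering group carries the rise. Nothing available here bears on the reason for it.

As far as these compounds go, whether a carboxylic acid at the end of this chain, or a plain longer alkyl chain, would do the same stays open. From the compounds shown here alone, whether the replacement acts alike on the core of compound 3 also stays open.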